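The compounds below may be only part of what the source reports. "The series", "measured", "known", "first", "only" and "open" are said of these compounds alone.

For the measured compounds named here, compound 3 `Nc1nc(NCc2ccccc2F)nc(-c2c(F)cccc2CO)n1` is one of three compounds measured in a functional assay on cells for positive allosteric modulation of G-protein coupled receptor 68 (Homo sapiens), read by a luciferase reporter and cAMP accumulation, with a stated time of 30 min, at pH 6.8 and pH 8.3, in the presence of a further agent that is not named here; a lower number here means a less potent compound, a higher number a more potent compound, by a factor of ten per unit of this negative logarithm. In this assay compound 3 gives 4.22, the lowest of the three numbers, although all three lie within the scatter of one another: compound 1 `Nc1nc(NCc2ccccc2F)nc(-c2ccccc2CO)n1` gives 4.27 and compound 2 `Cc1cccc(CNc2nc(N)nc(-c3ccccc3CO)n2)c1` gives 4.4. The step from compound 3 to compound 4 `Cc1cccc(CNc2nc(N)nc(-c3c(F)cccc3CO)n2)c1` is 3-methylphenyl in place of 2-fluorophenyl on a saturated chain carbon bound to a nitrogen on an aromatic ring. Going by the values given here, one measured step bears directly on it, since the same exchange on the same saturated chain carbon gave a number 0.13 log units higher from compound 1 to compound 2 (within the scatter). The other measured step, a number 0.05 log units lower from compound 1 to compound 3 (within the scatter), also stayed within the scatter, so the fluoro on the aromatic carbon that compound 3 and compound 4 share has not by itself moved the number. Among the compounds with values here, because the only comparable exchange gave a number 0.13 log units higher from compound 1 to compound 2 (within the scatter), no shift beyond the scatter is expected in this assay, and the step is expected to be about a number 0.13 log units higher from compound 3 to compound 4 (within the scatter). Compound 4 is therefore estimated at 4.35, with a likely range from 4 to 4.7.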

Compound 4, negative logarithm of the antagonist equilibrium constant: 4.44
Compound 4: the middle estimate sits 0.09 log units below what was measured; low and high end bracket the measured number.
By their numbers in this assay, from the lowest: compounds 3, 1, 2 and 4 (each within the scatter of the next).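

In this assay the exchange of 2-fluorophenyl for 3-methylphenyl on a saturated chain carbon bound to a nitrogen on an aromatic ring has now been read on a second core, giving a number 0.22 log units higher from compound 3 to compound 4 (within the scatter), and it stays of like size on both: the same change on two cores in this assay, a number 0.13 log units higher (within the scatter) from compound 1 to compound 2 and a number 0.22 log units higher (within the scatter) from compound 3 to compound 4, 0.09 log units apart, within the scatter of two such steps The fluoro on the aromatic carbon has likewise been read with 3-methylphenyl in place, giving a number 0.04 log units higher from compound 2 to compound 4 (within the scatter), and it too holds on both cores: the same change on two cores in this assay, a number 0.05 log units lower (within the scatter) from compound 1 to compound 3 and a number 0.04 log units higher (within the scatter) from compound 2 to compound 4, 0.09 log units apart, within the scatter of two such steps Each of the two changes therefore reads the same whichever form of the other is present, and none of these steps leaves the scatter.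

As far as these compounds go, what remains open is whether anything at this position can move the number beyond the scatter. An amine, a carboxylic acid or a longer chain in place of the 3-methylphenyl could answer that, but the compounds shown do not.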